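Acetyl for fluoro on the fused ring of compound 3

The compounds below may be only part of what the source reports. "The series", "measured", "known", "first", "only" and "open" are said of these compounds alone.

Of the compounds shown here, three have been measured in a functional assay on HEK293 cells for agonist activity at Free fatty acid receptor 1 (Homo sapiens), read by fluorescence and calcium flux, with a stated time of 10 min; on this read-out higher numbers stand for an effect only at larger amounts of compound and lower numbers for an effect already at smaller amounts. Compound 1 `COc1ccc2c(c1)OC(COc1ccc(CCC(=O)O)c(F)c1)CC2` gives 2110 nM. Compound 2 `CS(=O)(=O)CCCOc1ccc2c(c1)OC(COc1ccc(CCC(=O)O)c(F)c1)CC2` gives 36300 nM, and the step of a 17-fold higher number from compound 1 to compound 2 (1.24 log units; beyond the scatter) shows how strongly a 2-(methylsulfonyl)ethyl in place of hydrogen on a saturated chain carbon bound to an oxygen on an aromatic ring weakens the response. Compound 3 `CC#C[C@@H](CC(=O)O)c1ccc(OC[C@H]2COc3ccc(F)cc3O2)cc1` gives 210 nM, the lowest number of the three, beyond the scatter from both others; it is the most potent compound measured here.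

Compound 4 `CC#C[C@@H](CC(=O)O)c1ccc(OC[C@H]2COc3ccc(C(C)=O)cc3O2)cc1` differs from compound 3 in one place: acetyl in place of fluoro on an aromatic carbon. Going by the values given here, no measured step covers an acetyl in place of fluoro; the only step available, that from compound 1 to compound 2, concerns a different group on the fused ring and is large. It shows that the fused ring tolerates change poorly when a substituent grows, but the acetyl is far smaller than that chain, so only a modest weakening is expected. The estimated step of a 2.1-fold higher number from compound 3 to compound 4 (0.33 log units; beyond the scatter) is therefore expected to be small to moderate, toward higher numbers. Compound 4 is estimated at 450 nM, with a range from 120 nM to 1700 nM.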

Compound 4, half-maximal effective concentration: > 30000 nM
Compound 4 ended at the assay's limit (the forecaster's own chance of this, stated with the estimate: 2%); at least 66-fold (1.82 log units) between middle value and limit.
By their numbers in this assay, from the lowest: compound 3; then compound 1; then compound 2.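

In this assay, acetyl in place of fluoro on an aromatic carbon, meta to a fused ring and para to a fused ring, gives an at least 140-fold higher number from compound 3 to compound 4 (2.15 log units; beyond the scatter), so this position does not take the acetyl while keeping the response seen with fluoro. Compound 4 gives > 30000 nM, which is a limit of the assay and not a number: the limit of > 30000 nM in this assay, at which 1 of the 4 values shown sits. Going by these compounds alone, the only earlier step, a 17-fold higher number from compound 1 to compound 2 (1.24 log units; beyond the scatter), came with the entry of a 2-(methylsulfonyl)ethyl on a different core, whereas this result shows that a group of just 3 heavy atoms, entering for fluoro, is also enough for a large step.

The compounds shown leave open whether the large step goes with the carbonyl of the acetyl or with the larger group as a whole, a question that a plain ethyl or a methyl at this position, set against a nitrile, would help to separate. They also leave open whether a chloro here would stay close to compound 3 at 210 nM, or whether fluoro is the exception at this aromatic carbon.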